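The source may report more compounds than this note shows. Statements on the series, on what has been measured and on what is new or still open speak of the compounds shown alone.

Compound 1 `COc1ccc(/C=C/C(=O)c2ccccc2-c2ccc(F)cc2)cc1OC` and compound 2 `COc1ccc(/C=C/C(=O)c2ccccc2-c2ccc(F)nc2)cc1OC` share one core; compound 3 `COc1cc(C(=O)/C=C/c2ccccc2-c2ccc(F)cc2)ccc1O` and compound 4 `COc1cc(C(=O)/C=C/c2ccccc2-c2ccc(F)nc2)ccc1O` share another, and the difference between the two cores is not broken down here. In a functional assay on A549 cells (Homo sapiens) for antiproliferative activity, read by sulforhodamine B assay, with a stated time of 48 h (on this read-out higher numbers stand for weaker inhibition and lower numbers for stronger inhibition), compound 1 gives 440 nM, and compound 2 gives 1200 nM. The change from compound 1 to compound 2 is 6-fluoropyridin-3-yl in place of 4-fluorophenyl on an aromatic carbon, and it made a 2.7-fold higher number from compound 1 to compound 2 (0.44 log units; beyond the scatter). Compound 3, in this assay, gives 4600 nM, the highest of the three numbers and beyond the scatter from both others. Compound 4 carries the same change on the core of compound 3: 6-fluoropyridin-3-yl in place of 4-fluorophenyl on an aromatic carbon. The change occurs only twice among these compounds; the one measured step is the only guide to the second. The step from compound 3 to compound 4 is expected to be a 2.6-fold higher number from compound 3 to compound 4 (0.42 log units; beyond the scatter), set alongside the earlier step and resting on the size of a 2.7-fold higher number from compound 1 to compound 2 (0.44 log units; beyond the scatter) on the other core. Compound 4 is therefore expected to give about 12000 nM in this assay, with a range from 5000 nM to 30000 nM.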

Compound 4, half-maximal inhibitory concentration: 13000 nM
Estimate against measurement, compound 4: 1.1-fold (0.03 log units) below, and the stated range covers the measured number.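

In this assay, 6-fluoropyridin-3-yl in place of 4-fluorophenyl on an aromatic carbon gave a 2.8-fold higher number from compound 3 to compound 4 (0.45 log units; beyond the scatter). The size of the step carried over from one core to the other: the same change on two cores in this assay, a 2.7-fold higher number (0.44 log units; beyond the scatter) from compound 1 to compound 2 and a 2.8-fold higher number (0.45 log units; beyond the scatter) from compound 3 to compound 4, 1.0-fold (0.02 log units) apart, within the scatter of two such steps

This rests on one pair of compounds on each of two cores in a single cell assay, so it supports carrying the step between these two cores only; it does not show that the step would hold on a further core or on another read-out, and it gives no cause for the step.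

Going by these compounds, whether the step holds with an amine or a methoxy group in place of the fluorine stays open. On these data alone, compound 1 and compound 3 differ in more than one place, and which of those differences carries the gap between them also stays open.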